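Compound 1 to compound 4: swapping the acetyl group

The source may hold more compounds than are shown below. What is called first, only, known or untested is meant among the compounds shown, and "the series" means these compounds.

Measured in a functional assay on HT-29 cells (Homo sapiens) for cytotoxicity; on this read-out higher numbers stand for weaker inhibition and lower numbers for stronger inhibition:
- compound 1 `CC(=O)n1nc(N)c2c(-c3ccccc3)c(-c3ccccc3)nnc21`: > 100000 nM
- compound 2 `CC(=O)Nc1nn(C(C)=O)c2nnc(-c3ccccc3)c(-c3ccccc3)c12`: > 100000 nM
- compound 3 `Nc1[nH]nc2nnc(-c3ccccn3)c(-c3ccccn3)c12`: 73000 nM

Compound 1 stands at > 100000 nM, which is a limit of the assay and not a number. Compound 2 gives > 100000 nM, which is also a limit. The series therefore offers the limit of > 100000 nM in this assay, at which 2 of the 3 values shown sit, as its main feature. For the measured compounds named here, the one measured step, a step that the two limits leave unreadable from compound 1 to compound 2, gives no size to carry forward. Going by the values given here, compound 3 gives the only true number, 73000 nM, but it differs from compound 1 in more than one place.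

Compound 4 `Nc1nn(COCCO)c2nnc(-c3ccccc3)c(-c3ccccc3)c12` carries (2-hydroxyethoxy)methyl in place of acetyl on an aromatic nitrogen. Among the compounds with values here, no measured step covers this change, so no step beyond the scatter is expected in this assay, and no direction is favoured. The expected step is a number no higher from compound 1 to compound 4 (the limit leaves the size open). A report at the limit again is the likeliest single outcome. For compound 4 the estimated value is 100000 nM, with an expected range of 40000 nM to 250000 nM.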

Compound 4, half-maximal inhibitory concentration: > 100000 nM
Compound 4: only a limit was reported; the forecaster's own chance of this, stated with the estimate: 60%; the middle value sits exactly at the limit.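

No step can be read between compound 1 and compound 4 in this assay, because both results are limits and not numbers: the limit of > 100000 nM in this assay, at which 3 of the 4 values shown sit.

The compounds shown leave open how (2-hydroxyethoxy)methyl and acetyl on the aromatic nitrogen compare in size of effect.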